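The source may report more compounds than this note shows. Statements on the series, on what has been measured and on what is new or still open speak of the compounds shown alone.

Measured compounds in a functional assay on ileum for inhibition of histamine H1 receptor (Cavia porcellus); on this read-out lower numbers stand for stronger inhibition and higher numbers for weaker inhibition:
- compound 1, `CN1CCN(c2nc3ccccc3n2-c2ccccc2)CC1`: 760 nM
- compound 2, `CCCSCn1c(N2CCN(C)CC2)nc2ccccc21`: 68 nM
- compound 3, `CCSCCCn1c(N2CCN(C)CC2)nc2ccccc21`: 530 nM

Compound 3 holds the second highest of the three numbers in this assay. Its nearest neighbour is compound 1, and the step of a 1.4-fold lower number from compound 1 to compound 3 (0.16 log units; within the scatter) lies within the scatter, so the two cannot be ordered. Its furthest neighbour is compound 2, and the step of a 7.8-fold higher number from compound 2 to compound 3 (0.89 log units; beyond the scatter) is beyond the scatter.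

Compound 4, `CCCC(C)Cn1c(N2CCN(C)CC2)nc2ccccc21`, differs from compound 3 in one place: 1-methylbutyl in place of 2-(ethylsulfanyl)ethyl on a saturated chain carbon bound to an aromatic nitrogen. Within the data shown here, two measured steps touch the same position. The step of an 11-fold lower number from compound 1 to compound 2 (1.05 log units; beyond the scatter) was large, and the step of a 7.8-fold higher number from compound 2 to compound 3 (0.89 log units; beyond the scatter) was modest. Neither step removes the sulfur from the chain altogether, so the data give no direct guide for a chain of carbon alone. On that basis, the step of a 1.3-fold lower number from compound 3 to compound 4 (0.12 log units; within the scatter) is expected to stay close to the scatter. For compound 4 an inhibitory concentration of 400 nM is estimated, with a range from 120 nM to 1300 nM.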

Compound 4, half-maximal inhibitory concentration: 500 nM
Estimate against measurement, compound 4: 1.3-fold (0.10 log units) below, within the range that was stated.
By their numbers in this assay, from the lowest: compound 2; then compounds 4, 3 and 1 (each within the scatter of the next).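

In this assay, the step of a 1.1-fold lower number from compound 3 to compound 4 (0.03 log units; within the scatter) shows that a chain of carbon alone, 1-methylbutyl, can stand where 2-(ethylsulfanyl)ethyl stood without a readable change, so sulfur in this chain is not needed to hold the number at this level. The step of a 7.4-fold higher number from compound 2 to compound 4 (0.87 log units; beyond the scatter) shows that the gap to compound 2 does not depend on sulfur being present in the other chain, since it remains when the chain has none, while the step of a 1.5-fold lower number from compound 1 to compound 4 (0.18 log units; within the scatter) leaves 2-methylpentyl and phenyl on the aromatic nitrogen unresolved. No measurement shown here accounts for these results.

Going by these compounds, it remains open how an unbranched pentyl chain would compare with 1-methylbutyl at this position. Also open, on these data alone, is whether an ether oxygen in place of the sulfur of propylsulfanyl would keep the number of compound 2.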